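The source may report more compounds than this note shows. Statements on the series, on what has been measured and on what is new or still open speak of the compounds shown alone.

Measured compounds:
compound 1 `CCOC(=O)CNC(C)(C)CC(=O)N[C@@H]1CCc2ccccc2N(Cc2ccc(-c3ccccc3-c3nn[nH]n3)cc2)C1=O` — 56 nM
compound 2 `C[C@H](O)CNC(C)(C)C(=O)N[C@@H]1CCc2ccccc2N(Cc2ccc(-c3ccccc3-c3nn[nH]n3)cc2)C1=O` — 700 nM

In a functional assay (Pituitary gland cell) with Rattus norvegicus as the target (a higher number here means that more compound is needed for the effect, a lower number that less compound is needed), compound 2 gives the highest number of the two measured compounds; the nearest is compound 1, and the step of a 13-fold higher number from compound 1 to compound 2 (1.10 log units; beyond the scatter) is large. Compound 3 `C[C@H](O)CCNC(C)(C)C(=O)N[C@@H]1CCc2ccccc2N(Cc2ccc(-c3ccccc3-c3nn[nH]n3)cc2)C1=O` differs from compound 2 by 2-hydroxypropyl in place of 1-hydroxyethyl on a saturated chain carbon bound to an amine nitrogen; read one bond further out, this is 2-hydroxypropyl to 3-hydroxybutyl on the amine nitrogen. For the measured compounds named here, no measured step covers this change: the single step of a 13-fold higher number from compound 1 to compound 2 (1.10 log units; beyond the scatter) swaps an ester-bearing chain for a hydroxyl-bearing one and shifts the chain length at the same time, so it does not isolate the homologation seen here. With the hydroxyl retained and the chain only extended, the expected step of a 1.2-fold lower number from compound 2 to compound 3 (0.07 log units; within the scatter) in this assay is none beyond the scatter. Compound 3 is therefore estimated at 600 nM, within 250 nM to 1500 nM.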

Compound 3, concentration for half-maximal effect: 50 nM
For compound 3 the middle estimate is 12-fold (1.08 log units) above the measured one; measured number below the stated range.
By their numbers in this assay, from the lowest: compounds 3 and 1 (each within the scatter of the next); then compound 2.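

In this assay, the step of a 14-fold lower number from compound 2 to compound 3 (1.15 log units; beyond the scatter) shows that this position is highly sensitive to extending 2-hydroxypropyl to 3-hydroxybutyl on the amine nitrogen, even though the hydroxyl is retained. The step of a 1.1-fold lower number from compound 1 to compound 3 (0.05 log units; within the scatter) shows that a hydroxyl-bearing side chain can match the ester-bearing side chain in this assay, so the ethoxycarbonyl group is not needed for a value in this range. No supporting measurement accounts for the size of the step from 2-hydroxypropyl to 3-hydroxybutyl.

On these data alone, it remains open whether a longer chain such as 4-hydroxypentyl would extend or reverse this gain, and whether a plain butyl chain would show that the hydroxyl is needed. The effects of the opposite configuration at the hydroxyl-bearing carbon, and of a carboxylic acid in place of the ethyl ester, are also unresolved.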